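Estimating compound 3 from a single flat step

The source may hold more compounds than are shown below. What is called first, only, known or untested is meant among the compounds shown, and "the series" means these compounds.

Measured in a functional assay on Hs 683 cells (Homo sapiens) for cytotoxicity, read by MTT assay; a higher number here means a weaker inhibitor, a lower number a stronger inhibitor:
Compound 1 `Oc1ccc(CN(Cc2cccc(C(F)(F)F)c2)Cc2ccc(O)c3ncccc23)c2cccnc12`: 36 nM
Compound 2 `Oc1ccc(CN(Cc2cccs2)Cc2ccc(O)c3ncccc23)c2cccnc12`: 35 nM

Compound 1 and compound 2 stand within the scatter of each other, with compound 2 at 35 nM. Compound 3 `O=C(O)C1CCC(CN(Cc2ccc(O)c3ncccc23)Cc2ccc(O)c3ncccc23)CC1` carries 4-carboxycyclohexyl in place of thiophen-2-yl on a saturated chain carbon bound to an amine nitrogen. Among the compounds with values here, the only measured step, a 1.0-fold lower number from compound 1 to compound 2 (0.01 log units; within the scatter), lies within the scatter, but it exchanged one aromatic group for another, so it offers only weak guidance for this change. A modest move towards a higher number is therefore expected, with a wide margin: a 2.6-fold higher number from compound 2 to compound 3 (0.41 log units; beyond the scatter). Compound 3 is estimated at 90 nM (range 25 nM to 350 nM).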

Compound 3, half-maximal inhibitory concentration: 2860 nM
The estimate for compound 3 lay 32-fold (1.50 log units) below the measured number, and the stated range ends below it.
By their numbers in this assay, from the lowest: compounds 2 and 1 (each within the scatter of the next); then compound 3.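

In this assay this position, on a saturated chain carbon bound to an amine nitrogen, proved far from indifferent: the flat exchange of one aromatic group for another gave way to an 82-fold higher number from compound 2 to compound 3 (1.91 log units; beyond the scatter) when 4-carboxycyclohexyl replaced thiophen-2-yl. Against 3-(trifluoromethyl)phenyl the same group gave a 79-fold higher number from compound 1 to compound 3 (1.90 log units; beyond the scatter) and so the loss does not depend on which aromatic group it replaces. Nothing available here explains this loss. The compounds shown leave open whether the carboxylic acid or the saturated cyclohexyl ring carries the change, as the two enter together. A plain cyclohexyl or a phenyl bearing a carboxylic acid would separate them.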